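The source may report more compounds than this note shows. Statements on the series, on what has been measured and on what is new or still open speak of the compounds shown alone.

Compound 1 `COc1ccc(N2C(=O)N(Cc3ccc(F)cc3Cl)c3ccccc3S2(=O)=O)cc1OC`: 25.1 nM
Compound 2 `COc1ccc(N2C(=O)N(Cc3c(F)cc(F)cc3Cl)c3ccccc3S2(=O)=O)cc1OC`: 1 nM

Going by the values given here, in an assay on HEK293 cells for displacement of a labelled ligand from Orexin receptor type 2 (Homo sapiens), read by scintillation counting, with a stated time of 90 min (a higher number here means a weaker inhibitor, a lower number a stronger inhibitor), compound 2 stands lowest of the two numbers measured so far; the nearest is compound 1, and the step of a 25-fold lower number from compound 1 to compound 2 (1.40 log units; beyond the scatter) was large. Compound 3 `COc1ccc(N2C(=O)N(Cc3c(F)cc(C)cc3Cl)c3ccccc3S2(=O)=O)cc1OC` differs from compound 2 by methyl in place of fluoro on an aromatic carbon, turning the 2-chloro-4,6-difluorobenzyl group into a 2-chloro-6-fluoro-4-methylbenzyl group. Among the compounds with values here, only that single step touches this carbon, and it shows that what sits on it matters strongly; no measured step exchanges fluoro for methyl. A modest step in this assay, expected as a 2.5-fold higher number from compound 2 to compound 3 (0.40 log units; beyond the scatter), seems most likely. Compound 3 is therefore estimated at 2.5 nM, within 0.6 nM to 10 nM.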

Compound 3, inhibition constant: 0.794 nM
Compound 3: the middle estimate sits 3.1-fold (0.50 log units) above what was measured; the range from low to high includes it.
By their numbers in this assay, from the lowest: compounds 3 and 2 (each within the scatter of the next); then compound 1.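

In this assay, the step of a 1.3-fold lower number from compound 2 to compound 3 (0.10 log units; within the scatter) shows that this carbon, para to a large group, accepts methyl as well as fluoro, with no difference that can be told from the scatter. The wider step of a 32-fold lower number from compound 1 to compound 3 (1.50 log units; beyond the scatter) stays large, so the strong binding seen with compound 2 survives this exchange. No outside evidence here accounts for this result. Still open, as far as these compounds go, is whether this carbon would also accept something bigger or charged, such as a methoxy group, an amine or a carboxylic acid.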